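From dimethylamino to morpholin-4-yl on a carbonyl carbon

The compounds below may be only part of what the source reports. "The series", "measured", "known", "first", "only" and "open" are said of these compounds alone.

Compound 1 (`C=C(C)Cn1cc(/C=C/C(=O)CC(=O)C(=O)O)c2ccccc21`) gives 40000 nM
Compound 2 (`CN(C)C(=O)Cn1cc(/C=C/C(=O)CC(=O)C(=O)O)c2ccccc21`) gives > 40000 nM

In a functional assay on MOLT-4 cells (Homo sapiens) for inhibition, read by MTT assay, with a stated time of 48 h (on this read-out higher numbers stand for weaker inhibition and lower numbers for stronger inhibition), compound 2 gives > 40000 nM as a limit and not as a number. Compound 3 (`O=C(/C=C/c1cn(CC(=O)N2CCOCC2)c2ccccc12)CC(=O)C(=O)O`) carries morpholin-4-yl in place of dimethylamino on a carbonyl carbon. Going by the values given here, the only measured step that bears on this change is a number no lower from compound 1 to compound 2 (the limit leaves the size open) and its size stays open, so it points to no sizeable shift. Compound 2 also offers only the limit of > 40000 nM in this assay, at which 1 of the 2 values shown sits, as a starting point. The estimated step of a number no higher from compound 2 to compound 3 (the limit leaves the size open) is expected to stay within the usual scatter. For compound 3 the expected value is 40000 nM with an estimated range of 20000 nM to 80000 nM in this assay as well.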

Compound 3, half-maximal inhibitory concentration: > 40000 nM
Compound 3: no number, only a limit (the forecaster's own chance of this, stated with the estimate: 75%); the middle value sits exactly at the limit.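

In this assay compound 3 gives > 40000 nM, which is a limit and not a number. The step from dimethylamino to morpholin-4-yl on the carbonyl carbon therefore cannot be read, and the other new step has a direction but no readable size: a number no lower from compound 1 to compound 3 (the limit leaves the size open). Morpholin-4-yl thus adds a further compound at the same limit: the limit of > 40000 nM in this assay, at which 2 of the 3 values shown sit.

Going by these compounds, whether any group on this carbonyl carbon can give a measured number remains open. A primary amine or a carboxylic acid on the saturated chain carbon could test this.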